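From Fluoro to Methoxy: One Untested Swap

A few compounds are considered here, and "the series" means these few. Any claim that something is new, unique, unknown or untested is made for them only; others in the source may bear on it.

- compound 1 `Cc1occc1C(=O)NC(=O)c1ccccc1O` gives 16 ug/mL
- compound 2 `O=C(NC(=O)c1ccccc1O)c1ccc(F)cc1` gives 38 ug/mL

Both compounds were tested in an ADME assay on L6 cells (Rattus norvegicus) for cytotoxicity, read by resazurin assay, with a stated time of 72 h; on this read-out lower numbers stand for stronger inhibition and higher numbers for weaker inhibition. Of the two numbers, compound 2 has the higher one at 38 ug/mL, and the gap down to compound 1 at 16 ug/mL lies beyond the usual scatter of repeated measurements.

Compound 3 `COc1ccc(C(=O)NC(=O)c2ccccc2O)cc1` has not been measured yet. It keeps the core of compound 2 and changes one group, with methoxy in place of fluoro on an aromatic carbon, para to a large group (methoxy in place of fluoro on an aromatic carbon).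

Within the data shown here, no measured pair shows what this single change does in this assay, so the expectation is a cautious one. Among the measured compounds shown here, the only guide is the span from compound 1 at 16 ug/mL to compound 2 at 38 ug/mL. Within that span, no step beyond the scatter is expected. The estimate amounts to an expected 1.3-fold lower number from compound 2 to compound 3 (0.10 log units; within the scatter). For compound 3 the estimated value is 30 ug/mL, with an expected range from 12 ug/mL to 75 ug/mL.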

Compound 3, half-maximal inhibitory concentration: 39 ug/mL
The estimate for compound 3 lay 1.3-fold (0.11 log units) below the measured number, and the stated range covers the measured number.
By their numbers in this assay, from the lowest: compound 1; then compounds 2 and 3 (each within the scatter of the next).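

In this assay, among these compounds, the swap of fluoro for methoxy on this aromatic carbon, para to a large group, can now be read directly for the first time, and the step is a 1.0-fold higher number from compound 2 to compound 3 (0.01 log units; within the scatter) for this pair. Methoxy brings 2 heavy atoms and 1 hydrogen-bond acceptor where fluoro had 1 heavy atom and no acceptor, yet the two compounds cannot be told apart on this read-out, so at this position the added atom and acceptor leave no measurable mark in this one pair. Nothing else measured on these compounds bears on why the two groups read alike.

A single pair at a single position cannot show whether every group at this place would read the same, and an amine, a carboxylic acid or a longer chain such as butoxy could still move the number beyond the scatter. On these data alone, it also remains open whether swapping fluoro for methoxy would give the same near-zero step at another place on the ring, or on a different core such as that of compound 1.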